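A few compounds are considered here, and "the series" means these few. Any claim that something is new, unique, unknown or untested is made for them only; others in the source may bear on it.

Compound 1 `COc1ccc(-n2nncc2CN2C(=O)C3(C(C#N)=C(N)Oc4c(N)cc5nc6ccccc6nc5c43)c3ccccc32)cc1`: > 50000 nM
Compound 2 `N#CC1=C(N)Oc2c(N)cc3nc4ccccc4nc3c2C12C(=O)N(Cc1cnnn1-c1ccc([N+](=O)[O-])cc1)c1ccccc12`: > 50000 nM

In a functional assay on HCT-116 cells (Homo sapiens) for antiproliferative activity, read by MTT assay, with a stated time of 48 h (a lower number here means a stronger inhibitor, a higher number a weaker inhibitor), compound 1 gives only a limit, > 50000 nM. Compound 2 likewise gives only a limit, > 50000 nM. For the measured compounds named here, the single measured step, a step that the two limits leave unreadable from compound 1 to compound 2, cannot be read in size because of the limit of > 50000 nM in this assay, at which 2 of the 2 values shown sit. Compound 3 `N#CC1=C(N)Oc2c(N)cc3nc4ccccc4nc3c2C12C(=O)N(Cc1cnnn1-c1ccc([N+](=O)[O-])cc1[N+](=O)[O-])c1ccccc12` differs from compound 2 by nitro in place of hydrogen on an aromatic carbon. With both measured values sitting at a limit, no step size can be drawn from them, and compound 3 is expected to stay at or near that same limit, a step of a number no higher from compound 2 to compound 3 (the limit leaves the size open). Compound 3 is therefore estimated at 50000 nM, within a range from 20000 nM to 200000 nM.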

Compound 3, half-maximal inhibitory concentration: 23900 nM
Beside the measured number, compound 3's estimate is 2.1-fold (0.32 log units) above it; the measured number falls inside the stated range.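

In this assay the change from 4-nitrophenyl to 2,4-dinitrophenyl gives an at least 2.0-fold lower number from compound 2 to compound 3 (0.32 log units; beyond the scatter) and so brings the series off the limit of the assay. Set against the methoxy compound, the same ring gives an at least 2.0-fold lower number from compound 1 to compound 3 (0.32 log units; beyond the scatter) as well. This aromatic carbon, ortho to a large group, is therefore the first place in the set where a change shows up as a real number, while the earlier step between limits cannot be read.

As far as these compounds go, it remains open whether this gain belongs to the nitro group itself or would come with any group on this carbon; an amine or a chlorine atom there would separate the two.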